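Adding an ester to a weak compound

A few compounds are considered here, and "the series" means these few. Any claim that something is new, unique, unknown or untested is made for them only; others in the source may bear on it.

Compound 1 (`COc1cc(-c2ccnc3cc(-c4cccc(C#N)c4)nn23)cc(OC)c1OC`): > 10000 nM
Compound 2 (`COc1cc(-c2ccnc3cc(-c4ccccc4)nn23)cc(OC)c1OC`): 4730 nM

For the measured compounds named here, in a functional assay on B16-F0 cells (Mus musculus) for inhibition, read by CCK-8 assay, with a stated time of 48 h (a higher number here means a weaker inhibitor, a lower number a stronger inhibitor), compound 2 gives 4730 nM as the only true number so far. The entry for compound 1 is a limit of the assay, not a number.

Compound 3 (`CCOC(=O)c1ccc(-c2cc3nccc(-c4cc(OC)c(OC)c(OC)c4)n3n2)cc1`) keeps the core of compound 2 and takes ethoxycarbonyl in place of hydrogen on an aromatic carbon of a six-membered aromatic ring of carbon only, para to a large group (ethoxycarbonyl in place of hydrogen on an aromatic carbon).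

Going by the values given here, one measured step bears on this change. Hydrogen in place of cyano on an aromatic carbon gave an at least 2.1-fold lower number from compound 1 to compound 2 (0.32 log units; beyond the scatter), so adding a group back to that ring may be expected to weaken the compound by a modest amount. This is a single case with a different group, and it starts from the limit of > 10000 nM in this assay, at which 1 of the 2 values shown sits, so it is only a loose guide.

The expected change is a 1.5-fold higher number from compound 2 to compound 3 (0.17 log units; within the scatter), towards a higher number in this assay. For compound 3 the estimated value is 7000 nM, with an expected range from 2500 nM to 20000 nM.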

Compound 3, half-maximal inhibitory concentration: > 10000 nM
Compound 3: only a limit was reported; the forecaster's own chance of this, stated with the estimate: 40%; middle value at least 1.4-fold (0.15 log units) from the limit.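

In this assay compound 3 gives > 10000 nM, which is a limit of the assay and not a number. Ethoxycarbonyl in place of hydrogen on the carbon-only aromatic ring, para to a large group, gives an at least 2.1-fold higher number from compound 2 to compound 3 (0.32 log units; beyond the scatter), so this ester at this position costs activity rather than adding any, and the nitrile of compound 1 is no longer the only group on that ring to go with weaker inhibition than hydrogen. How large the loss really is cannot be read, because the result for compound 3 ends at the assay's limit and gives only a lower bound: the limit of > 10000 nM in this assay, at which 2 of the 3 values shown sit.

With ethoxycarbonyl as the only group shown at this position, it stays open whether the position itself resists substitution or whether this particular ester is the problem. A small group such as methyl or methoxy, or a carboxylic acid or an amine in the same place, could separate these two readings and might give a true number in this assay.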